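The compounds below may be only part of what the source reports. "The series", "measured", "known", "first", "only" and "open" are said of these compounds alone.

Measured compounds in the series:
- compound 1 `Cc1cc(C)cc(S(=O)(=O)c2c(C(=O)NCc3ccccc3)[nH]c3ccc([N+](=O)[O-])cc23)c1`: 8000 nM
- compound 2 `Cc1cc(C)cc(S(=O)(=O)c2c(C(=O)NCCOc3ccccc3)[nH]c3ccc(Cl)cc23)c1`: 207000 nM
- compound 3 `Cc1cc(C)cc(S(=O)(=O)c2c(C(=O)NCc3ccccc3)[nH]c3ccc(Cl)cc23)c1`: 244000 nM

In an ADME assay on CCRF-CEM cells (Homo sapiens) for cytotoxicity, read by cell counting (on this read-out lower numbers stand for higher toxicity in this test and higher numbers for lower toxicity in this test), compound 1 stands at the lowest number of the three, and the two other numbers lie well apart from it: a 31-fold higher number from compound 1 to compound 3 (1.48 log units; beyond the scatter), while the number of compound 2 sits close to that of compound 3. Going by the values given here, the one comparison on the amide side chain, a 1.2-fold higher number from compound 2 to compound 3 (0.07 log units; within the scatter), shows that swapping groups on the saturated chain carbon bound to the amide-type nitrogen left the number essentially where it was.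

Compound 4 `Cc1cc(C)cc(S(=O)(=O)c2c(C(=O)NCN3CCCC3)[nH]c3ccc([N+](=O)[O-])cc23)c1` keeps the nitro group and the shared core of compound 1 and differs from it only by pyrrolidin-1-yl in place of phenyl on a saturated chain carbon bound to an amide-type nitrogen. Among the compounds with values here, no measured step introduces pyrrolidin-1-yl, so the expectation rests on the one change at this place, which stayed within the scatter, and on the nitro group being unchanged. The expected step is therefore small: a 1.1-fold higher number from compound 1 to compound 4 (0.05 log units; within the scatter). For compound 4 in this assay the estimate is 9000 nM, with a range from 2500 nM to 35000 nM.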

Compound 4, half-maximal cytotoxic concentration: 12000 nM
For compound 4 the middle estimate is 1.3-fold (0.12 log units) below the measured one; the range from low to high includes it.
By their numbers in this assay, from the lowest: compounds 1 and 4 (each within the scatter of the next); then compounds 2 and 3 (each within the scatter of the next).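

In this assay, the change on the saturated chain carbon bound to an amide-type nitrogen gives a 1.5-fold higher number from compound 1 to compound 4 (0.18 log units; within the scatter), so replacing phenyl, a six-membered aromatic ring of carbon only, with pyrrolidin-1-yl, a five-membered non-aromatic ring with a hetero atom and a hydrogen-bond acceptor, leaves the number unresolved from that of the parent. The earlier side-chain comparison, a 1.2-fold higher number from compound 2 to compound 3 (0.07 log units; within the scatter), came from the chloro compounds and involved phenoxymethyl and phenyl, whereas this step extends the same within-scatter outcome to a nitro pair and to a ring of a different kind. The series offers no measurement that explains why the number holds across this change.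

Still open, on these data alone, is whether the large nitro-to-chloro step, a 31-fold higher number from compound 1 to compound 3 (1.48 log units; beyond the scatter), seen with the benzylcarbamoyl side chain, carries over to the ((pyrrolidin-1-yl)methyl)carbamoyl side chain. The compounds shown also leave open whether this place stays as tolerant with a carboxylic acid, an open-chain amine such as dimethylamino, or a longer chain between the amide nitrogen and the terminal ring.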